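Swapping the Small Ring on the Urea Side Chain

This account rests on a few compounds, and the source may have more. Where it says the series, first, only, none or still open, it means among the compounds named here.

Compound 1 `CCOC(=O)c1ccc(NC(=O)NCc2ccnnc2)cc1`: > 100000 nM (a limit)
Compound 2 `CCOC(=O)c1ccc(NC(=O)NCc2cnco2)cc1`: 6900 nM

In an assay on isolated protein for activation of Nicotinamide phosphoribosyltransferase (Homo sapiens) (on this read-out higher numbers stand for an effect only at larger amounts of compound and lower numbers for an effect already at smaller amounts), compound 2 gives 6900 nM, the only number shown. For compound 1 the value is a limit of the assay (the limit of > 100000 nM in this assay, at which 1 of the 2 values shown sits), not a number. For the measured compounds named here, the one measured step, an at least 14-fold lower number from compound 1 to compound 2 (1.16 log units; beyond the scatter), shows how strongly this ring matters. Compound 3 `CCOC(=O)c1ccc(NC(=O)NCc2ccncn2)cc1` carries the change (pyrimidin-4-yl in place of 1,3-oxazol-5-yl on a saturated chain carbon bound to an amide-type nitrogen). Because an at least 14-fold lower number from compound 1 to compound 2 (1.16 log units; beyond the scatter) was large when a six-membered ring with two nitrogens left, a return to such a ring is expected to weaken, so compound 3 is estimated at 30000 nM (range 6000 nM to 150000 nM), an expected step of a 4.3-fold higher number from compound 2 to compound 3 (0.64 log units; beyond the scatter).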

Compound 3, half-maximal effective concentration: 13600 nM
Estimate against measurement, compound 3: 2.2-fold (0.34 log units) above; measured number inside the range.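

Ring size alone does not decide the result at this place: a six-membered ring with two nitrogens can match the five-membered 1,3-oxazol-5-yl, with a 2.0-fold higher number from compound 2 to compound 3 (0.29 log units; within the scatter). The two six-membered rings do differ, with an at least 7.3-fold lower number from compound 1 to compound 3 (0.86 log units; beyond the scatter), so pyrimidin-4-yl and pyridazin-4-yl are not interchangeable on this saturated chain carbon. The value of compound 1 is a limit of the assay, not a number: the limit of > 100000 nM in this assay, at which 1 of the 3 values shown sits.

Still open, on these data alone, is how a plain phenyl ring or a pyridin-4-yl ring would behave here. Also open, as far as these compounds go, is what a longer chain carrying these rings would do.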